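This account rests on a few compounds, and the source may have more. Where it says the series, first, only, none or still open, it means among the compounds named here.

Series notes, step from compound 1 to compound 4.

Compound 1 `Cc1cc(O)c(C(C)C)cc1-c1cc(-c2ccccc2Cl)c(C#N)c(=O)[nH]1` carries 2-chlorophenyl on the shared core. Going by the values given here, in a functional assay for inhibition, tested at 60 ug/mL (a higher number here means a stronger effect of the compound at the concentration tested, a lower number a weaker effect), compound 1 gives 26%, the lowest of the three values measured so far. Compound 2 `COc1ccc(-c2cc(-c3cc(C(C)C)c(O)cc3C)[nH]c(=O)c2C#N)cc1OC` has 3,4-dimethoxyphenyl in that position, and in this assay compound 2 gives 52%. Compound 3 `Cc1cc(O)c(C(C)C)cc1-c1cc(-c2ccc(N(C)C)cc2)c(C#N)c(=O)[nH]1` has 4-(dimethylamino)phenyl there, and in this assay compound 3 gives 53%. The values of compound 2 and compound 3 lie within the scatter of each other a number 1 percentage points higher from compound 2 to compound 3 (within the scatter), so no order between them is claimed.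

Compound 4 `COc1ccc(-c2cc(-c3cc(C(C)C)c(O)cc3C)[nH]c(=O)c2C#N)cc1` is not yet measured. It differs from compound 1 as follows: 4-methoxyphenyl in place of 2-chlorophenyl on an aromatic carbon.

Among the compounds with values here, two measured steps bear on this change, both leaving 2-chlorophenyl on the same aromatic carbon: a number 26 percentage points higher from compound 1 to compound 2 (beyond the scatter) and a number 27 percentage points higher from compound 1 to compound 3 (beyond the scatter). Both replacements moved the read-out upward by a modest amount beyond the scatter. The 4-methoxyphenyl entering in compound 4 shares a methoxy-bearing phenyl with compound 2, so a step of similar size and direction is expected, a number 22 percentage points higher from compound 1 to compound 4 (beyond the scatter).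

For compound 4 in this assay the expected value is 48%, with a range from 32% to 64%; a limit is not anticipated.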

Compound 4, a percentage reported as inhibition, at one concentration (the size of the read-out at that concentration, not a potency): 43%
Beside the measured number, compound 4's estimate is 5 percentage points above it; low and high end bracket the measured number.
By their numbers in this assay, from the lowest: compound 1; then compounds 4, 2 and 3 (each within the scatter of the next).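

In this assay the 4-methoxyphenyl group on this carbon, opposite the ring nitrogen, gives a number 17 percentage points higher from compound 1 to compound 4 (beyond the scatter), so a third replacement of 2-chlorophenyl lifts the read-out beyond the scatter, this time with a single methoxy on the incoming ring. Neither remaining comparison separates the new compound from its neighbours: the loss of one methoxy from the 3,4-dimethoxyphenyl group gives a number 9 percentage points lower from compound 2 to compound 4 (within the scatter), and methoxy in place of dimethylamino gives a number 10 percentage points lower from compound 3 to compound 4 (within the scatter), so in this set the second methoxy and the choice between methoxy and dimethylamino carry no readable effect. No measurement here bears on why these replacements differ from 2-chlorophenyl.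

All three replacements remove the chlorine and also move substitution away from the place it occupied on the ring, so the compounds shown cannot say which of these changes goes with the higher read-out. Plain phenyl and 4-chlorophenyl on this carbon would separate the two, and a carboxylic acid or a primary amine at the 4-position of the phenyl would show how far the flat response extends.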